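The compounds below may be only part of what the source reports. "The series", "measured", "known", "first", "only" and "open" are said of these compounds alone.

Measured in a functional assay on A2780 cells (Homo sapiens) for antiproliferative activity, read by sulforhodamine B assay, with a stated time of 48 h; on this read-out higher numbers stand for weaker inhibition of growth and lower numbers for stronger inhibition of growth:
- compound 1 `COC(=O)/C=C/OC[C@H]1OCCC[C@H]1O[Si](C)(C)C(C)(C)C`: 30000 nM
- compound 2 `COC(=O)CCOC[C@H]1OCCC[C@H]1O[Si](C)(C)C(C)(C)C`: > 100000 nM, a limit

Compound 2 is known only as a limit, > 100000 nM. Compound 3 `CC(C)(C)[Si](C)(C)O[C@@H]1CCCO[C@@H]1COCCCO` carries hydroxymethyl in place of methoxycarbonyl on a saturated chain carbon, two bonds along the chain from an oxygen on a saturated carbon. Cut one bond further out, this reads 2-(methoxycarbonyl)ethyl to 3-hydroxypropyl.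

Among the compounds with values here, the one measured step, an at least 3.3-fold higher number from compound 1 to compound 2 (0.52 log units; beyond the scatter), is at least modest and beyond the scatter, but it is a different change and it ends on a limit. Within the data shown here, no measured step covers this exchange, so only a modest move is expected in this assay, towards a lower number if any, and another limit is quite possible. The expected move is an at least 1.6-fold lower number from compound 2 to compound 3 (0.22 log units; that floor lies within the scatter). For compound 3 the estimate is 60000 nM, with an expected range of 20000 nM to 150000 nM.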

Compound 3, concentration for 50% growth inhibition: > 100000 nM
Compound 3: no number, only a limit; the forecaster's own chance of this, stated with the estimate: 55%; at least 1.6-fold (0.22 log units) between middle value and limit.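

In this assay compound 3 gives > 100000 nM, a limit, and the step from compound 2 to this compound cannot be read. 3-Hydroxypropyl in place of 2-(methoxycarbonyl)ethenyl gives an at least 3.3-fold higher number from compound 1 to compound 3 (0.52 log units; beyond the scatter), so the saturated chain on this oxygen now fails to give a number with either hydroxymethyl or methoxycarbonyl at its end. Among the compounds shown, only compound 1, with 2-(methoxycarbonyl)ethenyl, gives a number, and exchanging the end group of the saturated chain does not bring one back: the limit of > 100000 nM in this assay, at which 2 of the 3 values shown sit.

Open, as far as these compounds go, is whether a carboxylic acid or an amine at the end of the saturated chain, or a longer chain, would give a number in this assay. Also open, from the compounds shown here alone, is whether an unsaturated chain ending in hydroxymethyl would keep a number like that of compound 1.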